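This account rests on a few compounds, and the source may have more. Where it says the series, first, only, none or still open, it means among the compounds named here.

In a functional assay on HL-60 cells (Homo sapiens) for inhibition, read by MTT assay, with a stated time of 72 h (a higher number here means a weaker inhibitor, a lower number a stronger inhibitor), compound 1 `Cc1nc(-c2ccccc2)c(C(=O)N2CCN(c3cccc(C(N)=O)c3)CC2)o1` gives 71 nM and compound 2 `C=C(C)c1ccc(N2CCN(C(=O)c3oc(C)nc3-c3ccccc3)CC2)cc1` is reported as "not active" (no number reported) without a number. Compound 3 `Cc1nc(-c2ccccc2)c(C(=O)N2CCN(c3ccc(C(F)(F)F)cc3)CC2)o1` stands at > 1000 nM as a limit of the assay and not a number. Compound 4 `CC(=O)Nc1cccc(N2CCN(C(=O)c3oc(C)nc3-c3ccccc3)CC2)c1` has 3-acetamidophenyl in place of 4-(trifluoromethyl)phenyl on an amine nitrogen in a ring and keeps the rest of compound 3 unchanged. For the measured compounds named here, one measured step bears on this change, namely an at least 14-fold higher number from compound 1 to compound 3 (1.14 log units; beyond the scatter) for 4-(trifluoromethyl)phenyl in place of 3-carbamoylphenyl at the same place. Going by the values given here, that step is large, but it is a single pair and the entering group in compound 4 is not the same as the one in compound 1 at 71 nM so only part of that pair can be carried over. A sizeable move to a lower number is therefore expected in this assay and the estimated step is an at least 6.6-fold lower number from compound 3 to compound 4 (0.82 log units; beyond the scatter) with wide uncertainty. For compound 4 the estimate is 150 nM with an expected range from 30 nM to 900 nM in this reading.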

Compound 4, half-maximal inhibitory concentration: 329 nM
The estimate for compound 4 lay 2.2-fold (0.34 log units) below the measured number; low and high end bracket the measured number.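

In this assay, the amine nitrogen in the ring now carries a second group with a measured number, as 3-acetamidophenyl in place of 4-(trifluoromethyl)phenyl gives an at least 3.0-fold lower number from compound 3 to compound 4 (0.48 log units; beyond the scatter), so the lower number is not confined to 3-carbamoylphenyl. The two groups are not interchangeable, since acetamido in place of carbamoyl on an aromatic carbon gives a 4.6-fold higher number from compound 1 to compound 4 (0.67 log units; beyond the scatter). The first of these steps is only a minimum, because compound 3 is reported as a limit and not a number: the limit of > 1000 nM in this assay, at which 1 of the 4 values shown sits.

From the compounds shown here alone, it stays open how much of that step rests on the group and how much on its place, since 3-acetamidophenyl and 4-(trifluoromethyl)phenyl differ in both. Going by these compounds, it is also open whether an amine, a carboxylic acid or a longer acyl chain in place of carbamoyl would keep the number low.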